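The source may report more compounds than this note shows. Statements on the series, on what has been measured and on what is new or still open speak of the compounds shown alone.

Measured so far:
compound 1, `CCC(C)C(C(=O)Nc1ccc(C(C)=O)cc1)N(C(=O)c1ccccc1)S(=O)(=O)c1ccc(C)cc1`, 18.6%
compound 2, `CC(=O)c1ccc(NC(=O)CN(C(=O)c2ccccc2)S(=O)(=O)c2ccc([N+](=O)[O-])cc2)cc1`, 20.6%

In a functional assay for inhibition, read by spectrophotometry, with a stated time of 20 min, tested at 1 mg/mL (a higher number here means a stronger effect of the compound at the concentration tested, a lower number a weaker effect), compound 1 gives 18.6%. In this assay compound 2 gives 20.6%. Within the data shown here, the two numbers sit within the usual scatter of each other, so neither compound can be set apart from the other on this evidence, and no step between them is known. Compound 3, `CCC(C)C(C(=O)Nc1ccc(C(C)=O)cc1)N(C(=O)c1ccccc1)S(=O)(=O)c1ccc([N+](=O)[O-])cc1`, has not yet been measured. It differs from compound 2 in one place: sec-butyl in place of hydrogen on a saturated chain carbon bound to an amide-type nitrogen and a carbonyl carbon. Compound 1 already carries this same sec-butyl group and gives a number in the same band as compound 2, so the account expects no step beyond the scatter from compound 2 to compound 3. The estimated step is a number 0.6 percentage points lower from compound 2 to compound 3 (within the scatter). For compound 3 the expected inhibition in this assay is 20%, with a range from 8% to 34%.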

Compound 3, a percentage reported as inhibition, at one concentration (the size of the read-out at that concentration, not a potency): 28.6%
The estimate for compound 3 lay 8.6 percentage points below the measured number; measured number inside the range.
By their numbers in this assay, from the lowest: compounds 1, 2 and 3 (each within the scatter of the next).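

In this assay, sec-butyl in place of hydrogen on a saturated chain carbon bound to an amide-type nitrogen and a carbonyl carbon gives a number 8 percentage points higher from compound 2 to compound 3 (within the scatter), so this position now has a direct one-place comparison, and the step stays within the scatter. Nitro in place of methyl on an aromatic carbon gives a number 10 percentage points higher from compound 1 to compound 3 (within the scatter), which is the first one-place reading of that change and also lies within the scatter. Nothing available explains either step. The compounds shown leave open whether any group at either position can produce a step beyond the scatter. A benzyl group or a longer chain on the saturated chain carbon, or an amine or a carboxylic acid in place of nitro on the aromatic carbon, could each test this.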